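Shifting a Methoxy Group: What to Expect of Compound 4

This account rests on a few compounds, and the source may have more. Where it says the series, first, only, none or still open, it means among the compounds named here.

Measured so far in a functional assay on COLO 205 cells (Homo sapiens) for cytotoxicity, read by MTT assay, with a stated time of 72 h; on this read-out lower numbers stand for stronger inhibition and higher numbers for weaker inhibition:
compound 1 `COc1ccc(/C=C/C(=O)Nc2cc(C(=O)c3cc(OC)c(OC)c(OC)c3)ccc2OC)cc1` gives 10900 nM;
compound 2 `COc1cccc(/C=C/C(=O)Nc2cc(C(=O)c3cc(OC)c(OC)c(OC)c3)ccc2OC)c1` gives 5100 nM;
compound 3 `COc1ccc(/C=C/C(=O)Nc2cc(C(=O)c3cc(OC)c(OC)c(OC)c3)cc(OC)c2OC)cc1` gives 4800 nM.

Compound 4 `COc1cccc(/C=C/C(=O)Nc2cc(C(=O)c3cc(OC)c(OC)c(OC)c3)cc(OC)c2OC)c1` has not yet been measured. It stands to compound 3 as compound 2 stands to compound 1: the same change, made on two different cores. Between compounds 1 and 2 the change is 3-methoxyphenyl in place of 4-methoxyphenyl on a double-bonded chain carbon bound to a double-bonded chain carbon, and it brought a 2.1-fold lower number from compound 1 to compound 2 (0.33 log units; beyond the scatter). The two cores differ in that compound 3 carries methoxy in place of hydrogen on an aromatic carbon relative to compound 1, a change that on its own gave a 2.3-fold lower number from compound 1 to compound 3 (0.36 log units; beyond the scatter). From compound 3 to compound 4 the change is 3-methoxyphenyl in place of 4-methoxyphenyl on a double-bonded chain carbon bound to a double-bonded chain carbon, at the very same place as before, so it is fairly called the same change.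

For the measured compounds named here, with only one earlier example, the expectation rests on that single pair. For compound 4 the expected step is a 2.0-fold lower number from compound 3 to compound 4 (0.30 log units; within the scatter), set beside the earlier 2.1-fold lower number from compound 1 to compound 2 (0.33 log units; beyond the scatter), on the assumption that the two changes add up rather than interfere. Compound 4 is therefore estimated at 2400 nM in this assay, with a plausible range from 1200 nM to 5000 nM.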

Compound 4, half-maximal inhibitory concentration: 10700 nM
Compound 4: middle estimate off by 4.5-fold (0.65 log units), on the low side, outside the stated range (above it).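

On the core that carries the extra methoxy, putting 3-methoxyphenyl in place of 4-methoxyphenyl in this assay gave a 2.2-fold higher number from compound 3 to compound 4 (0.35 log units; beyond the scatter), so the step that had lowered the number on the core of compound 1 now raised it: the same change on two cores in this assay, a 2.1-fold lower number (0.33 log units; beyond the scatter) from compound 1 to compound 2 and a 2.2-fold higher number (0.35 log units; beyond the scatter) from compound 3 to compound 4, 4.8-fold (0.68 log units) apart, beyond the scatter of two such steps. Read the other way round, adding the methoxy to the core of compound 2 gave a 2.1-fold higher number from compound 2 to compound 4 (0.32 log units; beyond the scatter), again the reverse of what the same addition did on the core of compound 1: the same change on two cores in this assay, a 2.3-fold lower number (0.36 log units; beyond the scatter) from compound 1 to compound 3 and a 2.1-fold higher number (0.32 log units; beyond the scatter) from compound 2 to compound 4, 4.8-fold (0.68 log units) apart, beyond the scatter of two such steps. This shows that in these four compounds neither change can be carried from one core to the other, since the outcome of each depends on whether the other is present, but it does not show why this happens or whether it holds for any compounds beyond these four.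

The compounds shown leave open whether this reversal is particular to methoxy, which a hydroxy group or a fluorine at the same places on the ring could test. They also leave open whether the same reversal would appear in a second cell line.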